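Carbamate to urea on the aryl sulfonamide series

The compounds below may be only part of what the source reports. "The series", "measured", "known", "first", "only" and "open" are said of these compounds alone.

Going by the values given here, compound 1 `CCCOC(=O)Nc1ccc(S(=O)(=O)N2C[C@H](c3ccccc3)NC2=O)cc1CC` sets the bar here: in a functional assay on A549 cells (Homo sapiens) for cytotoxicity, read by MTT assay (a higher number here means a weaker inhibitor, a lower number a stronger inhibitor), compound 1 gives 60 nM, the lowest of the two numbers so far. Among the compounds with values here, compound 2 `CCOC(=O)Nc1ccc(S(=O)(=O)N2C(=O)N[C@@H](c3ccccc3)C2C)cc1Cl` gives 6000 nM in this assay, a gap far beyond the scatter, but the two differ in several places and no single step connects them. Compound 3 `CCc1cc(S(=O)(=O)N2C[C@H](c3ccccc3)NC2=O)ccc1NC(=O)NC(C)C` awaits measurement; it differs from compound 1 by isopropylamino in place of propoxy on a carbonyl carbon. Within the data shown here, with no measured step of this kind, the step of a 1.7-fold higher number from compound 1 to compound 3 (0.22 log units; within the scatter) is expected to be small, at most a modest loss. Compound 3 is estimated at 100 nM in this assay, ranging from 30 nM to 400 nM.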

Compound 3, half-maximal inhibitory concentration: 100 nM
Compound 3: the middle estimate sits on the measured number at the digits printed; the range from low to high includes it.
By their numbers in this assay, from the lowest: compounds 1 and 3 (each within the scatter of the next); then compound 2.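

In this assay the series now has a step in one place, a 1.7-fold higher number from compound 1 to compound 3 (0.22 log units; within the scatter), so isopropylamino in place of propoxy on a carbonyl carbon gives a number within the scatter on the core of compound 1. Exchanging the carbamate for the urea, with one more hydrogen-bond donor and one fewer acceptor in the group, therefore costs nothing measurable at this position. Nothing at hand bears on why the two groups read alike.

As far as these compounds go, whether this tolerance extends to a longer chain, a cyclic amine such as morpholine or a carboxylic acid on this carbonyl carbon stays open. Going by these compounds alone, the gap to compound 2 also remains unassigned, as no single step connects it to compound 1 or compound 3.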